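From Compound 3 to Its Amino Analogue, Compound 4

The source may report more compounds than this note shows. Statements on the series, on what has been measured and on what is new or still open speak of the compounds shown alone.

In a functional assay on HepG2 cells (Homo sapiens) for cytotoxicity, read by MTT assay, with a stated time of 48 h (on this read-out higher numbers stand for weaker inhibition and lower numbers for stronger inhibition), compound 1 `Cc1ncc([N+](=O)[O-])n1CCSc1nnc(-c2ccc(F)cc2)o1` gives 600 nM, compound 2 `Cc1ncc([N+](=O)[O-])n1CCSc1nnc(-c2ccccn2)o1` gives 20200 nM, and compound 3 `Cc1ncc([N+](=O)[O-])n1CCSc1nnc(-c2cccnc2)o1` gives 9600 nM, the second highest of the three numbers. Compound 4 `Cc1ncc([N+](=O)[O-])n1CCSc1nnc(-c2ccc(N)nc2)o1` carries amino in place of hydrogen on an aromatic carbon of compound 3, next to the ring nitrogen and para to a large group: amino in place of hydrogen on an aromatic carbon. Going by the values given here, no measured step adds this group, so only exchanges of the whole aromatic group bear on it. Two of these are large, a 34-fold higher number from compound 1 to compound 2 (1.53 log units; beyond the scatter) and a 16-fold higher number from compound 1 to compound 3 (1.20 log units; beyond the scatter), and one is modest, a 2.1-fold lower number from compound 2 to compound 3 (0.32 log units; beyond the scatter). A single added amino is a smaller change than these, so in this assay the expected step is small, a 1.6-fold lower number from compound 3 to compound 4 (0.20 log units; within the scatter). Compound 4 is expected at 6000 nM, with an estimated range of 1500 nM to 24000 nM.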

Compound 4, half-maximal inhibitory concentration: 9400 nM
For compound 4 the middle estimate is 1.6-fold (0.19 log units) below the measured one; the measured number falls inside the stated range.
By their numbers in this assay, from the lowest: compound 1; then compounds 4 and 3 (each within the scatter of the next); then compound 2.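

In this assay, amino on an aromatic carbon next to the ring nitrogen and para to a large group does not separate the two compounds: a 1.0-fold lower number from compound 3 to compound 4 (0.01 log units; within the scatter). The 6-aminopyridin-3-yl group stays clear of both remaining compounds, with a 2.1-fold lower number from compound 2 to compound 4 (0.33 log units; beyond the scatter) and a 16-fold higher number from compound 1 to compound 4 (1.19 log units; beyond the scatter). No outside measurement bears on this result.

From the compounds shown here alone, whether a dimethylamino or methoxy group at this position would also leave the number in place remains open. So does the effect of amino on the 4-fluorophenyl group of compound 1.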